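A Second Chloroquinoline on the Triazole Nitrogen

This account rests on a few compounds, and the source may have more. Where it says the series, first, only, none or still open, it means among the compounds named here.

Compound 3 `CN(CCNCc1cn(CCCO)nn1)CCNc1ccnc2cc(Cl)ccc12` is the weakest of the three measured compounds. In a functional assay on NCI-H460 cells (Homo sapiens) for antiproliferative activity, read by sulforhodamine B assay, with a stated time of 72 h (a lower number here means a stronger inhibitor, a higher number a weaker inhibitor), compound 3 gives only a limit of the assay, > 200000 nM. Compound 1 `CN(CCNCc1cn(-c2ccccc2Cl)nn1)CCNc1ccnc2cc(Cl)ccc12` gives 20000 nM in this assay, and compound 2 `CN(CCNCc1cn(C(C)(C)C)nn1)CCNc1ccnc2cc(Cl)ccc12` gives 79000 nM. The step from compound 1 to compound 3 was an at least 10-fold higher number from compound 1 to compound 3 (1.00 log units; beyond the scatter), and that from compound 2 to compound 3 was an at least 2.5-fold higher number from compound 2 to compound 3 (0.40 log units; beyond the scatter). Compound 4 `CN(CCNCc1cn(-c2ccnc3cc(Cl)ccc23)nn1)CCNc1ccnc2cc(Cl)ccc12` carries the change (7-chloroquinolin-4-yl in place of 3-hydroxypropyl on an aromatic nitrogen). This runs against the direction of both measured steps and restores a ring-bearing group of the kind seen in compound 1. Compound 4 is therefore expected to show an at least 13-fold lower number from compound 3 to compound 4 (1.12 log units; beyond the scatter), with an estimated 15000 nM and a range from 4000 nM to 60000 nM.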

Compound 4, half-maximal inhibitory concentration: 16000 nM
Estimate against measurement, compound 4: 1.1-fold (0.03 log units) below; measured number inside the range.
By their numbers in this assay, from the lowest: compounds 4 and 1 (each within the scatter of the next); then compound 2. At a limit, above all of these: compound 3.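

In this assay, within the data shown here, 7-chloroquinolin-4-yl on the aromatic nitrogen gives a 4.9-fold lower number from compound 2 to compound 4 (0.69 log units; beyond the scatter), while against 2-chlorophenyl it gives a 1.3-fold lower number from compound 1 to compound 4 (0.10 log units; within the scatter), so the larger second chloroquinoline adds nothing measurable over the single ring of compound 1. Against 3-hydroxypropyl the change gives an at least 12-fold lower number from compound 3 to compound 4 (1.09 log units; beyond the scatter). Compound 3 stands only at a limit of the assay, so this step has a floor and no exact size: the limit of > 200000 nM in this assay, at which 1 of the 4 values shown sits.

On these data alone, it remains open whether an unsubstituted phenyl or a benzyl group on this nitrogen would match compound 1 and compound 4. As far as these compounds go, the effect of a chain ending in an amine or a carboxylic acid also remains open.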